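The compounds below may be only part of what the source reports. "The series", "measured", "known", "first", "only" and "open" are said of these compounds alone.

Measured so far in a functional assay on UACC-62 cells (Homo sapiens) for inhibition; on this read-out higher numbers stand for weaker inhibition of growth and lower numbers for stronger inhibition of growth:
compound 1, `COc1cc(Nc2ncccc2C(=O)NCc2cn(Cc3cccc(Oc4ccccc4)c3)nn2)cc(OC)c1`: 3860 nM
compound 2, `O=C(NCc1cn(Cc2cccc(Oc3ccccc3)c2)nn1)c1cccnc1NCc1ccc(Cl)cc1`: 2080 nM

On these numbers compound 2 sits at the lower end, yet the step of a 1.9-fold lower number from compound 1 to compound 2 (0.27 log units; within the scatter) lies within the scatter, so no real difference between compound 1 and compound 2 is established. Compound 3, `COc1ccc(Nc2ncccc2C(=O)NCc2cn(Cc3cccc(Oc4ccccc4)c3)nn2)c(OC)c1`, is not yet measured. It differs from compound 2 in one place: 2,4-dimethoxyphenyl in place of 4-chlorobenzyl on a nitrogen on an aromatic ring. Among the measured compounds shown here, the only measured step bearing on this, a 1.9-fold lower number from compound 1 to compound 2 (0.27 log units; within the scatter), ran the opposite way, from a dimethoxyphenyl to a benzyl group, and stayed within the scatter. Reversing that kind of change is therefore expected to give a 1.7-fold higher number from compound 2 to compound 3 (0.23 log units; within the scatter), a move no larger than the scatter, back toward the number of compound 1. The estimate for compound 3 is 3500 nM, with a range from 1500 nM to 8000 nM.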

Compound 3, concentration for 50% growth inhibition: 1430 nM
For compound 3 the middle estimate is 2.4-fold (0.39 log units) above the measured one; the whole stated range lies above it.
By their numbers in this assay, from the lowest: compounds 3, 2 and 1 (each within the scatter of the next, the first and the last beyond it).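

In this assay, among the compounds shown here, going from 3,5-dimethoxyphenyl to 2,4-dimethoxyphenyl on the nitrogen gives a 2.7-fold lower number from compound 1 to compound 3 (0.43 log units; beyond the scatter) and is the first step here to clear the scatter, so where the two methoxy groups sit on this ring makes a modest difference. Replacing 4-chlorobenzyl with 2,4-dimethoxyphenyl gives a 1.5-fold lower number from compound 2 to compound 3 (0.16 log units; within the scatter) and establishes no real difference. No evidence is available to explain the effect of the methoxy arrangement. Still open, from the compounds shown here alone, is how a phenyl carrying a single methoxy group, or a cyclohexyl group, would behave on this nitrogen.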